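Nitro in Place of Fluoro: An Expected Potency Shift

The source may hold more compounds than are shown below. What is called first, only, known or untested is meant among the compounds shown, and "the series" means these compounds.

compound 1: `CC(C)COc1cc(C(F)(F)F)ccc1CNC(=O)C(C)c1ccc(NS(C)(=O)=O)c(F)c1` — 0.8 nM
compound 2: `CC(C(=O)NCc1ccc(C(F)(F)F)cc1F)c1ccc(NS(C)(=O)=O)c(F)c1` — 68.7 nM
compound 3: `CC(C(=O)NCc1ccc(C(F)(F)F)cc1[N+](=O)[O-])c1ccc(NS(C)(=O)=O)c(F)c1` — not yet measured

In an assay on CHO cells for antagonist activity at transient receptor potential cation channel subfamily V member 1 (Homo sapiens), read by FLIPR (a lower number here means a stronger inhibitor, a higher number a weaker inhibitor), compound 1 gives 0.8 nM, and compound 2 gives 68.7 nM. Among the measured compounds shown here, compound 2 therefore stands at the weak end of the two measured numbers, its only neighbour being compound 1, reached by the single measured step, an 86-fold higher number from compound 1 to compound 2 (1.93 log units; beyond the scatter). Compound 3 differs from compound 2 at that same aromatic carbon: nitro in place of fluoro on an aromatic carbon. For the measured compounds named here, the one measured step shows that this carbon tolerates a large change, but it concerns a different group and gives no direct reading on a nitro. The expectation for compound 3 in this assay is thus a small step toward a lower number, of a size near the scatter, namely a 1.7-fold lower number from compound 2 to compound 3 (0.23 log units; within the scatter). Compound 3 is estimated to give 40 nM, with a plausible range from 10 nM to 200 nM.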

Compound 3, inhibition constant: "not active" (no number reported)
Compound 3: no number reported; no gap can be computed for the estimate.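

In this assay, among the compounds shown here, compound 3 is reported as not active, with no number, so no step from compound 2 to compound 3 can be read. Nothing shown here accounts for this result. The compounds shown leave open how weak compound 3 is.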